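Small Steps on One Aromatic Carbon

The source may hold more compounds than are shown below. What is called first, only, known or untested is meant among the compounds shown, and "the series" means these compounds.

In an ADME assay on MT4 cells (Homo sapiens) for cytotoxicity, read by MTT assay, with a stated time of 4 days (a higher number here means that more compound is tolerated, a lower number that less compound is tolerated), compound 1 (`Cc1ccc(-c2c(C)c(-c3ccc4c(c3)CCO4)c(C(OC(C)(C)C)C(=O)O)c(C)c2NS(C)(=O)=O)cc1C`) gives 38000 nM and compound 2 (`Cc1ccc(-c2c(C)c(-c3ccc4c(c3C)CCCO4)c(C(OC(C)(C)C)C(=O)O)c(C)c2NS(C)(=O)=O)cc1C`) gives 24000 nM while compound 3 (`Cc1ccc(-c2c(C)c(-c3ccc(Cl)c(F)c3)c(C(OC(C)(C)C)C(=O)O)c(C)c2NS(C)(=O)=O)cc1C`) gives 22000 nM so all three lie within the scatter of one another. The unmeasured compound 4 (`Cc1ccc(-c2c(C)c(-c3ccc4c(c3)CCCO4)c(C(OC(C)(C)C)C(=O)O)c(C)c2NS(C)(=O)=O)cc1C`) differs from compound 3 in one group (a group of 10 heavy atoms (9 carbon, 1 oxygen; one six-membered non-aromatic ring with 1 hetero atom, one six-membered aromatic ring of carbon only) in place of a group of 8 heavy atoms (6 carbon, 1 fluorine, 1 chlorine; one six-membered aromatic ring of carbon only), on an aromatic carbon) on an aromatic carbon para to a methanesulfonamido group. Measured exchanges on that carbon all stayed within the scatter (a 1.7-fold lower number from compound 1 to compound 3 (0.24 log units; within the scatter)) (a 1.1-fold lower number from compound 2 to compound 3 (0.04 log units; within the scatter)) (a 1.6-fold lower number from compound 1 to compound 2 (0.20 log units; within the scatter)) and none points in a clear direction. No step beyond the scatter is therefore expected in this assay and the estimated step (a 1.3-fold higher number from compound 3 to compound 4 (0.10 log units; within the scatter)) is small. For compound 4 an expected value of 28000 nM is estimated, with 15000 nM to 50000 nM as the likely range.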

Compound 4, half-maximal cytotoxic concentration: 28000 nM
For compound 4 middle estimate and measured number coincide at the digits printed, within the range that was stated.
By their numbers in this assay, from the lowest: compounds 3, 2, 4 and 1 (each within the scatter of the next).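

In this assay, hydrogen in place of methyl on the aromatic ring of the entering group is the smallest single change yet at this position, and it stays within the scatter (a 1.2-fold higher number from compound 2 to compound 4 (0.07 log units; within the scatter)). Going from the five-membered to the six-membered oxygen ring (a 1.4-fold lower number from compound 1 to compound 4 (0.13 log units; within the scatter)) and replacing 4-chloro-3-fluorophenyl (a 1.3-fold higher number from compound 3 to compound 4 (0.10 log units; within the scatter)) also stay within the scatter, so neither ring size nor either aromatic group stands apart here. No available measurement offers an explanation for these small steps. Still open, from the compounds shown here alone, is whether a group carrying an amine or a carboxylic acid on this carbon would give a step beyond the scatter.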